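Replacing the oxadiazolone of compound 3 with a primary amide

The source may report more compounds than this note shows. Statements on the series, on what has been measured and on what is new or still open speak of the compounds shown alone.

The series shares one core and varies the group on the branched side chain. In a functional assay on CHO cells for antagonist activity at prostaglandin E2 receptor EP3 subtype (Homo sapiens), read by cAMP accumulation (a higher number here means a weaker inhibitor, a lower number a stronger inhibitor), compound 1 `CC(C)C(c1ccc(-c2ccc3cccc(F)c3c2)[nH]c1=O)N1CCCCC1=O` gives 40 nM, compound 2 `Cc1nc(C(c2ccc(-c3ccc4cccc(F)c4c3)[nH]c2=O)C(C)C)[nH]c1C` gives 50 nM and compound 3 `CC(C)C(Cc1noc(=O)[nH]1)c1ccc(-c2ccc3cccc(F)c3c2)[nH]c1=O` gives 70 nM. Among the measured compounds shown here, compound 3 holds the highest number of the three, but the steps of a 1.8-fold higher number from compound 1 to compound 3 (0.24 log units; within the scatter) and a 1.4-fold higher number from compound 2 to compound 3 (0.15 log units; within the scatter) both lie within the scatter, as does a 1.3-fold higher number from compound 1 to compound 2 (0.10 log units; within the scatter), so no compound is set apart from the others here.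

Compound 4 `CC(C)C(CC(N)=O)c1ccc(-c2ccc3cccc(F)c3c2)[nH]c1=O` is not yet measured in this assay. It differs from compound 3 by a group of 3 heavy atoms (1 carbon, 1 nitrogen, 1 oxygen; no ring) in place of a group of 6 heavy atoms (2 carbon, 2 nitrogen, 2 oxygen; one five-membered aromatic ring with 3 hetero atoms), on a saturated chain carbon, two bonds along the chain from an aromatic carbon.

For the measured compounds named here, the steps that bear on this change are the three at the same side chain, each exchanging one group for another of seven heavy atoms: all stayed within the scatter. The change to compound 4 removes a ring altogether and leaves an open carbamoyl, a smaller change in atom count than any step yet seen, and the side-chain exchanges so far have not moved the number beyond the scatter. An expected step of a 1.4-fold higher number from compound 3 to compound 4 (0.15 log units; within the scatter) in this assay is therefore essentially flat, with the uncertainty widened because no open-chain group has been tested at this position. For compound 4 the estimate in this assay is 100 nM, with a range from 35 nM to 300 nM.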

Compound 4, half-maximal inhibitory concentration: 53 nM
The estimate for compound 4 lay 1.9-fold (0.28 log units) above the measured number; the measured number falls inside the stated range.
By their numbers in this assay, from the lowest: compounds 1, 2, 4 and 3 (each within the scatter of the next).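

In this assay, among the compounds shown here, the group at this position no longer needs a ring: the carbamoyl, on a saturated chain carbon two bonds along the chain from an aromatic carbon, gives a 1.3-fold lower number from compound 3 to compound 4 (0.12 log units; within the scatter) and a 1.1-fold higher number from compound 2 to compound 4 (0.03 log units; within the scatter) and a 1.3-fold higher number from compound 1 to compound 4 (0.12 log units; within the scatter) with no step separating it from the ring-bearing groups. Among these four compounds, neither the five-membered aromatic ring of compound 3 nor the ring groups of compound 1 and compound 2 are needed for a number in this range, and the exchange to a much smaller group of 3 heavy atoms leaves the series as flat as the exchanges between groups of equal size did. No measurement shown gives a reason for this flat behaviour.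

For the compounds shown here, what remains open is whether any group at this position can move the number beyond the scatter, since every step so far lies within it. A carboxylic acid or a primary amine on the same chain, or a longer chain carrying the carbamoyl, would show whether this tolerance extends past the neutral groups seen here.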